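The source may report more compounds than this note shows. Statements on the series, on what has been measured and on what is new or still open speak of the compounds shown alone.

Of the compounds shown here, three have been measured in a functional assay on SF-268 cells (Homo sapiens) for inhibition, read by sulforhodamine B assay, with a stated time of 48 h; on this read-out higher numbers stand for weaker inhibition of growth and lower numbers for stronger inhibition of growth. Compound 1 `COc1cc(-c2nn(-c3cccc(NC(=O)Nc4cc(C(F)(F)F)cc(C(F)(F)F)c4)c3)cc2-c2ccncc2)ccc1Cl` gives 978 nM. Compound 2 `COc1cc(-c2nn(-c3cccc(NC(=O)Nc4ccc(Cl)c(Cl)c4)c3)cc2-c2ccncc2)ccc1Cl` gives 1510 nM, the highest of the three numbers, though its distances to the other two lie within the scatter. Compound 3 `O=C(Nc1cccc(-n2cc(-c3ccncc3)c(-c3ccc(Cl)c(O)c3)n2)c1)Nc1ccc(Cl)c(Cl)c1` gives 1490 nM. Within the data shown here, the only single-point step recorded, a 1.0-fold lower number from compound 2 to compound 3 (0.01 log units; within the scatter), concerns hydrogen in place of methyl on an oxygen on an aromatic ring and moves nothing beyond the scatter. Compound 1 and compound 2 differ in the substituents of the outer ring on the urea, and their two numbers also sit within the scatter of each other.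

Compound 4 `COc1cc(-c2nn(-c3cccc(NC(=O)c4ccc(Cl)c(C(F)(F)F)c4)c3)cc2-c2ccncc2)ccc1Cl` has not been measured. It differs from compound 2 by 4-chloro-3-(trifluoromethyl)phenyl in place of (3,4-dichlorophenyl)amino on a carbonyl carbon, so the urea becomes an amide and the ring that enters carries a trifluoromethyl together with a chlorine. Among the measured compounds shown here, no measured step covers a change of this kind. For the measured compounds named here, what the data do show is that compound 1 and compound 2, which differ only in the substituents of this outer ring, stayed within the scatter, and that the one recorded step stayed within the scatter as well. Compound 4 is therefore expected to move little, the estimated step being a 1.0-fold lower number from compound 2 to compound 4 (0.00 log units; within the scatter). The estimate for compound 4 in this assay is 1500 nM, with a range from 500 nM to 4500 nM.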

Compound 4, concentration for 50% growth inhibition: 4860 nM
Compound 4: the middle estimate sits 3.2-fold (0.51 log units) below what was measured; measured number above the stated range.
By their numbers in this assay, from the lowest: compounds 1, 3 and 2 (each within the scatter of the next); then compound 4.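

In this assay, the change at this carbonyl carbon is the first among the compounds shown to pass beyond the scatter, with a 3.2-fold higher number from compound 2 to compound 4 (0.51 log units; beyond the scatter), a modest loss of growth inhibition. Compound 1 and compound 2, which both keep the urea and differ only in the substituents of the outer ring, stayed within the scatter of each other, so this position has now shown a response that substitution on a urea-linked ring did not show. Here, however, the amino nitrogen with its hydrogen-bond donor leaves while a trifluoromethyl also enters the ring, and no information given here explains the higher number or assigns it to either part of the change.

The compounds shown leave open whether the loss follows the amino nitrogen or the ring substitution, a question that a urea carrying 4-chloro-3-(trifluoromethyl)phenyl, or an amide carrying 3,4-dichlorophenyl, could settle. They also leave open how a methylene in that nitrogen's place, or a morpholine on the outer ring, would read in this assay.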